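Sulfonamide ether amides: bicyclic amine in place of diethylaminoethyl

This account rests on a few compounds, and the source may have more. Where it says the series, first, only, none or still open, it means among the compounds named here.

Three compounds have numbers in a functional assay on Umbilical vein for antagonist activity at B1 bradykinin receptor (Homo sapiens), using Schild analysis, with a stated time of 30 min; a lower number here means a less potent compound, a higher number a more potent compound, by a factor of ten per unit of this negative logarithm. Compound 1 `COc1cc(C)c(S(=O)(=O)N(C)CCOCC(=O)N2CCC(N3CCN(C(C)C)CC3)CC2)c(C)c1` gives 8.5. Compound 3 `COc1ccc(S(=O)(=O)N(C)CCOCC(=O)N(C)Cc2ccc(C3=NCCN3)cc2)c(C)c1` gives 8.6. Compound 2 `CCN(CC)CCN1CCN(C(=O)COCCN(C)S(=O)(=O)c2c(C)cc(OC)cc2C)CC1` gives 7.8, the lowest of the three; compound 1 stands higher by a margin beyond the scatter, and compound 3 stands higher by a slightly larger margin, also beyond the scatter.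

Compound 4 `COc1cc(C)c(S(=O)(=O)N(C)CCOCC(=O)N2CCN([C@H]3CN4CCC3CC4)CC2)c(C)c1` has not been measured in this assay. It differs from compound 2 in one place: a group of 8 heavy atoms (7 carbon, 1 nitrogen; 2 six-membered non-aromatic rings with 1 hetero atom each) in place of a group of 7 heavy atoms (6 carbon, 1 nitrogen; no ring), on an amine nitrogen in a ring. Within the data shown here, no step between two measured compounds isolates this change, so the size of the step must be judged from the spread of the three numbers.

Compound 4 is expected to move upward from compound 2, by a step of about a number 0.60 log units higher from compound 2 to compound 4 (beyond the scatter), because compound 1, which also carries a ring-containing amine at the amide end, gives 8.5. For compound 4 the estimate in this assay is therefore 8.4, with a range from 7.7 to 9.1.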

Compound 4, negative logarithm of the antagonist equilibrium constant: 7.2
Beside the measured number, compound 4's estimate is 1.20 log units above it; the whole stated range lies above it.
By their numbers in this assay, from the lowest: compound 4; then compound 2; then compounds 1 and 3 (each within the scatter of the next).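

In this assay, among these compounds, putting the bicyclic group in place of 2-(diethylamino)ethyl on the amine nitrogen in the ring gives a number 0.60 log units lower from compound 2 to compound 4 (beyond the scatter), the first step that isolates a single change. In this pair, therefore, tying the open chain into two six-membered non-aromatic rings lowers the number, and the equal counts of hydrogen-bond donors, acceptors and net charge for the two groups do not separate them. No measurement shown accounts for the fall.

The other stereoisomer of the bicyclic group stands open, so the role of its defined stereocentre cannot be judged. As far as these compounds go, it also remains open whether a single-ring group such as 1-methylpiperidin-4-yl or a shorter chain such as 2-(dimethylamino)ethyl on the same nitrogen would hold the number of compound 2.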